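Methyl Traded for Methoxy: An Expected Cytotoxicity Value

The compounds below may be only part of what the source reports. "The series", "measured", "known", "first", "only" and "open" are said of these compounds alone.

Of the compounds shown here, three have been tested in a toxicity assay on THP-1 cells (Homo sapiens) for cytotoxicity, read by MTT assay, with a stated time of 72 h; a higher number here means that more compound is needed for the effect, a lower number that less compound is needed. For compound 1 `Cn1c(/C=N/N=C(/N)S)cc2ccccc21` the result is only a limit, > 200000 nM. For compound 2 `CCCCn1cc(/C=N/NC(N)=S)c2cccc(C)c21` the result is likewise a limit, > 200000 nM. Among the measured compounds shown here, compound 3 `Cc1ccc(/C=N/NC(N)=S)c2ccccc12` is the one compound with a measured number in this assay, 32000 nM. The other two results sit at the limit of > 200000 nM in this assay, at which 2 of the 3 values shown sit. Compound 4 `COc1ccc(/C=N/NC(N)=S)c2ccccc12` has not yet been measured; it differs from compound 3 in one place, (methoxy in place of methyl on an aromatic carbon), that is, methoxy in place of methyl on an aromatic carbon. For the measured compounds named here, no step between measured compounds is available, so the expected step is modest, a 1.3-fold higher number from compound 3 to compound 4 (0.10 log units; within the scatter), not clearly beyond the scatter. For compound 4 the estimate in this assay is 40000 nM, within 15000 nM to 120000 nM.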

Compound 4, half-maximal effective concentration: 47000 nM
For compound 4 the middle estimate is 1.2-fold (0.07 log units) below the measured one; measured number inside the range.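

On this aromatic carbon, para to a group of 6 heavy atoms, methoxy in place of methyl gives a 1.5-fold higher number from compound 3 to compound 4 (0.17 log units; within the scatter) in this assay. The swap adds an oxygen and a hydrogen-bond acceptor, yet it does not separate the two compounds. Neither compound 3 nor compound 4 reaches the limit that bounds the other results: the limit of > 200000 nM in this assay, at which 2 of the 4 values shown sit.

Still open, on these data alone, is whether an amine or a carboxylic acid on this carbon would also stay close to compound 3. A single step also cannot show whether this swap behaves alike on another core.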